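This account rests on a few compounds, and the source may have more. Where it says the series, first, only, none or still open, it means among the compounds named here.

Compound 1 `CC(Sc1nc2c(cnn2C)c(=O)n1-c1ccccc1)c1ccccn1` is one of three compounds tested in an assay on isolated protein for inhibition of aldehyde dehydrogenase 1A1 (Homo sapiens) (a higher number here means a weaker inhibitor, a lower number a stronger inhibitor), where compound 1 gives 242 nM. That puts compound 1 second highest of the three numbers: compound 3 `CC(Sc1nc2nn(C3COC3)cc2c(=O)n1-c1ccccc1)c1cccnc1` gives 118 nM, a lower number beyond the scatter, and compound 2 `Cn1ncc2c(=O)n(-c3ccccc3)c(CCc3cccc(F)c3)nc21` gives 1000 nM, a higher number beyond the scatter. Compound 4 `CC(Sc1nc2c(cnn2C)c(=O)n1-c1ccccc1)c1ccccc1` has not yet been measured in this assay. It differs from compound 1 in one place: phenyl in place of pyridin-2-yl on a saturated chain carbon bound to a saturated chain carbon and a sulfur. Going by the values given here, no measured pair shows this change, so its size can only be expected, not read off. The step from compound 1 is expected to be small, within or near the scatter, with a slight lean toward a higher number, giving a 1.3-fold higher number from compound 1 to compound 4 (0.12 log units; within the scatter). Compound 4 is therefore estimated at 320 nM, within a range of 110 nM to 950 nM.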

Compound 4, half-maximal inhibitory concentration in the aldehyde dehydrogenase 1A1 assay: 130 nM
Compound 4: middle estimate off by 2.5-fold (0.39 log units), on the high side, and the stated range covers the measured number.
By their numbers in the aldehyde dehydrogenase 1A1 assay, from the lowest: compounds 3, 4 and 1 (each within the scatter of the next, the first and the last beyond it); then compound 2.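

Placing phenyl instead of pyridin-2-yl on this saturated chain carbon gives the first direct reading at this position: in the aldehyde dehydrogenase 1A1 assay the step is a 1.9-fold lower number from compound 1 to compound 4 (0.27 log units; within the scatter), so inhibition holds with the hydrogen-bond acceptor of pyridin-2-yl gone. The same change does separate the two compounds in a physicochemical assay for solubility, using the shake flask method, in phosphate buffer, with a stated time of 24 h, at pH 7.4 (a lower number here means a less soluble compound, a higher number a more soluble compound), where compound 1 gives 20000 nM and compound 4 gives 8000 nM: the measured solubility of compound 1, 20000 nM, and of compound 4, 8000 nM, a 2.5-fold lower number (0.40 log units; beyond the scatter)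

The compounds shown leave open whether an amine or a carboxylic acid in place of this ring would keep the inhibition while giving a higher solubility number.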